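Swapping chloro for fluoro on the central ring

A few compounds are considered here, and "the series" means these few. Any claim that something is new, unique, unknown or untested is made for them only; others in the source may bear on it.

Compounds measured in a functional assay on CHO cells for positive allosteric modulation of metabotropic glutamate receptor 2 (Homo sapiens), read by scintillation counting and GTPgammaS binding, with a stated time of 30 min; a lower number here means a smaller maximal response, a higher number a larger maximal response:
compound 1 `CC(C)CCn1ccc(-c2ccccc2)c(C#N)c1=O` gives 117%;
compound 2 `CCCCn1ccc(-c2ccc(Oc3ccnc(C)c3)cc2)c(C#N)c1=O` gives 243%;
compound 3 `CCCCn1ccc(-c2ccc(Oc3ccnc(C)c3)cc2Cl)c(C#N)c1=O` gives 187%.

In this assay compound 3 stands second highest of the three numbers, below compound 2 and well above compound 1, both gaps beyond the scatter. Compound 4 `CCCCn1ccc(-c2ccc(Oc3ccnc(C)c3)cc2F)c(C#N)c1=O` has not yet been measured. It differs from compound 3 in one place: fluoro in place of chloro on an aromatic carbon.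

Among the measured compounds shown here, one measured step bears on the spot in question. The step of a number 56 percentage points lower from compound 2 to compound 3 (beyond the scatter) shows that putting chloro at this place instead of hydrogen lowered the maximal response markedly. For the measured compounds named here, no measured pair shows what fluoro does there, so the expectation rests on that single step: with chloro leaving and a smaller halogen entering, compound 4 is expected to land between compound 3 and compound 2, an estimated upward step of a number 18 percentage points higher from compound 3 to compound 4 (beyond the scatter). For compound 4 in this assay a value of 205% is estimated, with a range from 160% to 250%.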

Compound 4, largest response reached (Emax), in percent of the reference or control that the assay uses: 232%
Compound 4: middle estimate off by 27 percentage points, on the low side, within the range that was stated.
By their numbers in this assay, from the lowest: compound 1; then compound 3; then compound 4; then compound 2.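

In this assay the identity of the halogen at this place, ortho to a large group, matters: fluoro in place of chloro gives a number 45 percentage points higher from compound 3 to compound 4 (beyond the scatter) and so recovers most of what chloro cost. Fluoro in place of hydrogen still gives a number 11 percentage points lower from compound 2 to compound 4 (beyond the scatter) as a modest step, so this aromatic carbon accepts fluoro far more readily than chloro, although neither halogen reaches the value of compound 2. No measurement at hand explains why the two halogens differ so much here.

On these data alone, whether a methyl, a methoxy or a trifluoromethyl group at this same place would land nearer compound 2 or compound 3 remains open. So does whether fluoro would give a similar result if the butyl chain on the core were replaced by a longer chain.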